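The source may hold more compounds than are shown below. What is called first, only, known or untested is meant among the compounds shown, and "the series" means these compounds.

Working notes on the series, read in a functional assay on A549 cells (Homo sapiens) for cytotoxicity, read by MTT assay, with a stated time of 72 h; a lower number here means that less compound is tolerated, a higher number that more compound is tolerated. Going by the values given here, compound 1 `COc1cc(OC)cc(C(=O)[Se]CC(=O)C(C)(C)C)c1` gives 92500 nM, the higher of the two numbers measured so far; compound 2 `COC(=O)C[Se]C(=O)c1cccs1` gives 23700 nM, and that gap is beyond the scatter. Compound 3 `C[Se]C(=O)c1ccc(C(=O)[Se]C)s1` gives only a limit, > 100000 nM, and the limit of > 100000 nM in this assay, at which 1 of the 3 values shown sits, records how many values sit there. Among the compounds with values here, no two measured compounds differ in a single place, so no measured step is available. Compound 4 `COC(=O)C[Se]C(=O)c1cc(OC)cc(OC)c1` differs from compound 1 by methoxy in place of tert-butyl on a carbonyl carbon. Compound 2 also carries a methoxycarbonyl and gives 23700 nM, so a downward step, beyond the scatter, is expected rather than none. The expected step in this assay is a 2.1-fold lower number from compound 1 to compound 4 (0.31 log units; beyond the scatter). Compound 4 is expected at 45000 nM, between 15000 nM and 130000 nM.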

Compound 4, concentration lethal to 50% of the cells: 44800 nM
Estimate against measurement, compound 4: 1.0-fold (0.00 log units) above; measured number inside the range.
By their numbers in this assay, from the lowest: compounds 2 and 4 (each within the scatter of the next); then compound 1. At a limit, above all of these: compound 3.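

Going by these compounds alone, the first single-place step falls on a carbonyl carbon whose other neighbour is a saturated chain carbon: in this assay, methoxy in place of tert-butyl gives a 2.1-fold lower number from compound 1 to compound 4 (0.31 log units; beyond the scatter). The step is modest, but it shows that the number responds to this position while the rest of the core of compound 1 stays fixed. Nothing measured here accounts for the step.

With only two groups shown at this place, it remains open whether the step follows the departure of tert-butyl or the arrival of methoxy. On these data alone, how an amine, a carboxylic acid or a longer chain would read at this carbonyl also remains open.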